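The compounds below may be only part of what the source reports. "The series", "measured", "known", "first", "only" and "open" are said of these compounds alone.

Notes on the series. Compound 1 `NNC(=O)c1c(NC(=O)NS(=O)(=O)c2ccccc2)sc2c1CCCCC2` in a functional assay on cells (Cancer cell lines, Homo sapiens) for inhibition, with a stated time of 48 h (on this read-out higher numbers stand for weaker inhibition of growth and lower numbers for stronger inhibition of growth), gives > 100000 nM, which is a limit of the assay rather than a number. Compound 2 `CN1CCN(C(=O)c2c(NC(=O)NS(=O)(=O)c3ccccc3)sc3c2CCCCC3)CC1` gives 56200 nM. Compound 3 `O=C(Nc1sc2c(c1C(=O)NNc1ccc(Br)cc1)CCCCC2)NS(=O)(=O)c1ccccc1` gives 25500 nM, the lowest of the two numbers; it stands a 2.2-fold lower number from compound 2 to compound 3 (0.34 log units; beyond the scatter) and an at least 3.9-fold lower number from compound 1 to compound 3 (0.59 log units; beyond the scatter). Compound 4 `CCCCNC(=O)c1c(NC(=O)NS(=O)(=O)c2ccccc2)sc2c1CCCCC2` differs from compound 3 by butyl in place of (4-bromophenyl)amino on an amide-type nitrogen. For the measured compounds named here, the steps that bear on this are an at least 3.9-fold lower number from compound 1 to compound 3 (0.59 log units; beyond the scatter), where the 4-bromophenyl group entering lowered the number, and a 2.2-fold lower number from compound 2 to compound 3 (0.34 log units; beyond the scatter). Taking that group away is expected to move the number back up; butyl is not hydrogen, and no measured step covers a plain alkyl here, so only a modest rise is expected. The expected step is a 2.2-fold higher number from compound 3 to compound 4 (0.33 log units; beyond the scatter). Compound 4 is estimated at 55000 nM, within 18000 nM to 150000 nM.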

Compound 4, concentration for 50% growth inhibition: 85300 nM
Compound 4: the middle estimate sits 1.6-fold (0.19 log units) below what was measured; measured number inside the range.
By their numbers in this assay, from the lowest: compound 3; then compounds 2 and 4 (each within the scatter of the next). At a limit, above all of these: compound 1.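

For the compounds shown here, on the amide-type nitrogen, the one clear change is a 3.3-fold higher number from compound 3 to compound 4 (0.52 log units; beyond the scatter), so butyl does not keep the lower number that goes with (4-bromophenyl)amino. With butylamino in place of 4-methylpiperazin-1-yl on a carbonyl carbon, the step is a 1.5-fold higher number from compound 2 to compound 4 (0.18 log units; within the scatter), so these two groups are not separated. Compound 1 gives a limit and not a number. With butyl in place of amino on an amide-type nitrogen, the step is an at least 1.1-fold lower number from compound 1 to compound 4 (0.06 log units; that floor lies within the scatter), which is only a floor, so this step cannot be read: the limit of > 100000 nM in this assay, at which 1 of the 4 values shown sits.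

Open, from the compounds shown here alone, is which part of (4-bromophenyl)amino goes with the lower number: the bromine, the aromatic ring or the added nitrogen. A plain phenylamino group or a longer alkyl chain would bear on this.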